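Changing the ring on the carbonyl carbon of compound 1

A few compounds are considered here, and "the series" means these few. Any claim that something is new, unique, unknown or untested is made for them only; others in the source may bear on it.

Compound 1 `COc1ccc(Br)cc1C(=O)Nc1ccc(Sc2nc3ccccc3s2)cc1` was examined in an assay for inhibition of HSP60/HSP10 (Homo sapiens), with a stated time of 60 min; a lower number here means a stronger inhibitor, a higher number a weaker inhibitor. In this assay compound 1 reaches only a limit of the assay, > 100000 nM. Compound 2 `O=C(Nc1ccccc1)c1cc(Br)cc(Br)c1O` gives in this assay a value of 63000 nM. Compound 3 `O=C(Nc1ccc(Sc2nc3ccccc3s2)cc1)c1cc(Br)cc(Br)c1O` remains to be measured in this assay. It differs from compound 1 in one place: 3,5-dibromo-2-hydroxyphenyl in place of 5-bromo-2-methoxyphenyl on a carbonyl carbon. The ring that enters is the same ring that compound 2 carries on its carbonyl carbon. Because of the limit of > 100000 nM in this assay, at which 1 of the 2 values shown sits, the step away from compound 1 cannot be sized from a measured number. Compound 3 is expected to give a weak result, with the step from compound 1 to compound 3 of an at least 1.6-fold lower number from compound 1 to compound 3 (0.22 log units; that floor lies within the scatter) taken as a move toward a stronger inhibitor that may still fall within the scatter. For compound 3 the estimate in this assay is 60000 nM, with a range from 15000 nM to 250000 nM.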

Compound 3, half-maximal inhibitory concentration: 4700 nM
The estimate for compound 3 lay 13-fold (1.11 log units) above the measured number, outside the stated range (below it).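

In this assay, 3,5-dibromo-2-hydroxyphenyl in place of 5-bromo-2-methoxyphenyl on a carbonyl carbon brings an at least 21-fold lower number from compound 1 to compound 3 (1.32 log units; beyond the scatter), so the ring at this position weighs heavily on the result for the core of compound 1. The size of this step is a floor and no more, and compound 1 gives only a limit of the assay, > 100000 nM, which points to the source of that floor: the limit of > 100000 nM in this assay, at which 1 of the 3 values shown sits. Compound 2, which carries the same ring, gives 63000 nM, while compound 3 gives 4700 nM, so the ring alone does not set the value.

The change swaps methoxy for hydroxy and adds a second bromine in one step, and the compounds shown do not separate the two. On these data alone, whether a 3,5-dichloro-2-hydroxyphenyl ring, or a carboxylic acid in place of the hydroxy group, would hold this value also remains open.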